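The source may hold more compounds than are shown below. What is called first, only, known or untested is meant among the compounds shown, and "the series" means these compounds.

Measured in a functional assay on BGC-823 cells (Homo sapiens) for inhibition, read by sulforhodamine B assay, with a stated time of 3 days; a higher number here means a weaker inhibitor, a lower number a stronger inhibitor:
- compound 1 `O=C1Nc2ccc(F)cc2/C1=C\C(=O)c1ccc(O)cc1F`: 6120 nM
- compound 2 `COc1ccc(C(=O)Nc2ccc3c(c2)/C(=C/Nc2cccc(N4CCN(C)CC4)c2)C(=O)N3)cc1`: 3170 nM

With only these two numbers, the series has little to go on. In this assay, compound 1 at 6120 nM and compound 2 at 3170 nM lie within the scatter of each other, so the data do not separate them. Going by the values given here, compound 2 therefore stands level with the only other measured compound.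

The next compound to be measured is compound 3 `CN1CCN(c2cccc(N/C=C3\C(=O)Nc4ccc(NC(=O)c5c(Cl)cccc5Cl)cc43)c2)CC1`. It differs from compound 2 by 2,6-dichlorophenyl in place of 4-methoxyphenyl on a carbonyl carbon whose other neighbours are: amide-type nitrogen (2,6-dichlorophenyl in place of 4-methoxyphenyl on a carbonyl carbon). The rest of the structure is unchanged.

Among the compounds with values here, no measured pair shows what a change at this place does, so the size of the step cannot be calibrated. Within the data shown here, the only anchor is compound 2 at 3170 nM, and no shift beyond the scatter in this assay is expected, in either direction. The expected step is a 1.1-fold lower number from compound 2 to compound 3 (0.05 log units; within the scatter), and the uncertainty around it is wide. For compound 3 the estimated value is 2800 nM, with an expected range of 800 nM to 9500 nM.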

Compound 3, half-maximal inhibitory concentration: 2240 nM
For compound 3 the middle estimate is 1.3-fold (0.10 log units) above the measured one; low and high end bracket the measured number.
By their numbers in this assay, from the lowest: compounds 3, 2 and 1 (each within the scatter of the next, the first and the last beyond it).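

In this assay, 2,6-dichlorophenyl in place of 4-methoxyphenyl on a carbonyl carbon whose other neighbour is an amide-type nitrogen gives a 1.4-fold lower number from compound 2 to compound 3 (0.15 log units; within the scatter). Going by these compounds alone, this is the only pair that reads this position, and it gives the position its first calibration: the hydrogen-bond acceptor of 4-methoxyphenyl has no counterpart in 2,6-dichlorophenyl, and chlorine takes the place of oxygen at an equal heavy-atom count, yet the two numbers are not separated in this assay. No measurement is available that bears on the reason for this result.

Within the data shown here, the pair compares only two substituted phenyl groups at this place, so it remains open whether a group of another kind, such as a longer chain carrying a carboxylic acid or an amine, would give a step beyond the scatter. Compound 1 differs from compound 2 and compound 3 in more than one place, so it adds no reading of this position.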